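The compounds below may be only part of what the source reports. "The series", "measured", "known", "first", "only" and "open" are said of these compounds alone.

Compound 1, `Cc1nc(NCC2CC2)nc(N[C@@H]2C[C@H](CO)[C@@H](O)[C@H]2O)c1-c1nc2ccccc2s1`, gives 8000 nM in an ADME assay on cells (Homo sapiens) for cytotoxicity, read by polymerase chain reaction, with a stated time of 3 days; on this read-out lower numbers stand for higher toxicity in this test and higher numbers for lower toxicity in this test.
Compound 2, `Cc1nc(NCCNC(=O)NC(C)(C)C)nc(N[C@@H]2C[C@H](CO)[C@@H](O)[C@H]2O)c1-c1nc2ccccc2s1`, gives > 25000 nM in this assay, a limit of the assay.

Compound 2 stands at the top of the measured range: its value in this assay is a limit of the assay and not a number, as shown by the limit of > 25000 nM in this assay, at which 1 of the 2 values shown sits. Compound 3, `Cc1nc(NCc2ccccn2)nc(N[C@@H]2C[C@H](CO)[C@@H](O)[C@H]2O)c1-c1nc2ccccc2s1`, differs from compound 2 by pyridin-2-yl in place of (((tert-butyl)carbamoyl)amino)methyl on a saturated chain carbon bound to a nitrogen on an aromatic ring. Within the data shown here, the one measured step that bears on this change is an at least 3.1-fold higher number from compound 1 to compound 2 (0.49 log units; beyond the scatter), where adding the (((tert-butyl)carbamoyl)amino)methyl group raised the number beyond the scatter. Compound 3 removes that same group and puts a pyridin-2-yl in its place, so part of that step is expected to be undone, with a modest fall back toward compound 1 rather than a return to it. The estimated step is an at least 2.0-fold lower number from compound 2 to compound 3 (0.31 log units; beyond the scatter), which for compound 3 means an expected value of 12000 nM in this assay, within a range from 5000 nM to 30000 nM.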

Compound 3, half-maximal cytotoxic concentration: 13000 nM
Beside the measured number, compound 3's estimate is 1.1-fold (0.03 log units) below it, within the range that was stated.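

Putting pyridin-2-yl in place of cyclopropyl gives a 1.6-fold higher number from compound 1 to compound 3 (0.21 log units; within the scatter), so in this assay a six-membered aromatic ring at this place cannot be told apart from the small saturated ring. Compound 2 carries a limit of the assay and not a number: the limit of > 25000 nM in this assay, at which 1 of the 3 values shown sits. Putting pyridin-2-yl in place of (((tert-butyl)carbamoyl)amino)methyl gives an at least 1.9-fold lower number from compound 2 to compound 3 (0.28 log units; that floor lies within the scatter), and with that floor inside the scatter this pair is not firmly separated, which leaves an at least 3.1-fold higher number from compound 1 to compound 2 (0.49 log units; beyond the scatter) as the only step among these compounds that is clearly larger than the scatter.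

A phenyl group at this place would test whether the nitrogen of the pyridin-2-yl ring matters at all for the read-out in this assay. From the compounds shown here alone, a longer chain ending in an amine or a carboxylic acid would test whether the number rises with the chain itself or only with the tert-butyl urea end of compound 2, whose true value stays unknown.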